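Swapping a chlorine-bearing chain for a silicon group

The source may report more compounds than this note shows. Statements on the series, on what has been measured and on what is new or still open speak of the compounds shown alone.

Measured in an ADME assay on HFF cells (Homo sapiens) for cytotoxicity, read by MTT assay, with a stated time of 72 h; on this read-out higher numbers stand for weaker inhibition and lower numbers for stronger inhibition:
- Compound 1 `CCCCCc1ccc(-c2cn(C[C@H](O)[C@H]3OC(=O)C(OCc4ccccc4)=C3OCc3ccccc3)nn2)cc1` gives > 100000 nM, a limit.
- Compound 2 `CCCCCCCCCCc1cn(C[C@H](O)[C@H]2OC(=O)C(OCc3ccccc3)=C2OCc2ccccc2)nn1` gives > 100000 nM, a limit.
- Compound 3 `O=C1O[C@H]([C@@H](O)Cn2cc(CCCCl)nn2)C(OCc2ccccc2)=C1OCc1ccccc1` gives 27100 nM.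

Going by the values given here, compound 3 is the only one with a real number, 27100 nM. The other two values sit at the limit of > 100000 nM in this assay, at which 2 of the 3 values shown sit.

Compound 4 `C[Si](C)(C)c1cn(C[C@H](O)[C@H]2OC(=O)C(OCc3ccccc3)=C2OCc2ccccc2)nn1` keeps the shared core but replaces the 3-chloropropyl group on the aromatic carbon: a group of 4 heavy atoms (3 carbon, 1 silicon; no ring) in place of a group of 4 heavy atoms (3 carbon, 1 chlorine; no ring), on an aromatic carbon.

Among the compounds with values here, two measured steps bear on this change: an at least 3.6-fold lower number from compound 1 to compound 3 (0.56 log units; beyond the scatter) and an at least 3.6-fold lower number from compound 2 to compound 3 (0.56 log units; beyond the scatter). Both arrive at the 3-chloropropyl group, and both sizes are only minimum sizes. Compound 4 gives that group up, so going by an at least 3.6-fold lower number from compound 2 to compound 3 (0.56 log units; beyond the scatter) a return toward a higher number is expected, though this rests on very few compounds.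

The expected step is a 2.2-fold higher number from compound 3 to compound 4 (0.35 log units; beyond the scatter), and a report of only a limit would be no surprise. For compound 4 the estimated value is 60000 nM, with an expected range of 20000 nM to 150000 nM.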

Compound 4, half-maximal inhibitory concentration: 20000 nM
Compound 4: the middle estimate sits 3.0-fold (0.48 log units) above what was measured; low and high end bracket the measured number.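

In this assay the swap gives a 1.4-fold lower number from compound 3 to compound 4 (0.13 log units; within the scatter), so the silicon-bearing group and the 3-chloropropyl group cannot be told apart on this aromatic carbon. Compound 4 also gives a real number rather than a limit, with an at least 5.0-fold lower number from compound 2 to compound 4 (0.69 log units; beyond the scatter) and an at least 5.0-fold lower number from compound 1 to compound 4 (0.69 log units; beyond the scatter), so among the compounds shown, a chlorine-bearing chain is not needed for a measurable value at this position. Those last two steps give minimum sizes only: the limit of > 100000 nM in this assay, at which 2 of the 4 values shown sit.

Whether silicon itself matters stays open, since a tert-butyl group, the all-carbon counterpart of the silicon-bearing group, is not among the compounds shown. From the compounds shown here alone, it is also open whether a plain propyl group would read like compound 3 and compound 4, or would instead reach the limit seen for compound 1 and compound 2.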